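Adding ethyl to a well-tolerated compound

The compounds below may be only part of what the source reports. "The series", "measured", "known", "first", "only" and "open" are said of these compounds alone.

- compound 1 `CC(C)Sc1nc(Cc2c(F)cccc2Cl)cc(=O)[nH]1`: > 80000 nM (a limit)
- compound 2 `Cc1c(Cc2c(F)cccc2Cl)nc(SC(C)C)[nH]c1=O`: > 76000 nM (a limit)
- compound 3 `CCCCSc1nc(Cc2c(F)cccc2Cl)c(C)c(=O)[nH]1`: > 73000 nM (a limit)

In an ADME assay on MT4 cells (Homo sapiens) for activation, read by MTT assay (a higher number here means that more compound is tolerated, a lower number that less compound is tolerated), compound 2 gives > 76000 nM. That value is a limit and not a number. The same holds for compound 1 and compound 3, so no measured cytotoxic concentration is available yet for any of the three.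

Compound 4 `CCC(c1nc(SC(C)C)[nH]c(=O)c1C)c1c(F)cccc1Cl` carries one change from compound 2: ethyl in place of hydrogen on a saturated chain carbon bound to two aromatic carbons. In words, it has ethyl in place of hydrogen on a saturated chain carbon bound to two aromatic carbons.

Going by the values given here, no measured step makes this same change, but two steps on the same series offer the nearest guide. Placing methyl in place of hydrogen on an aromatic carbon is a step that the two limits leave unreadable from compound 1 to compound 2. Placing butyl in place of isopropyl on a sulfur is a step that the two limits leave unreadable from compound 2 to compound 3. Neither has a size that can be read, so they give only weak guidance. All three compounds remain at limits in this assay, so a large step is not expected, and any shift is expected to be a modest fall in the tolerated concentration. The expected change is an at least 1.1-fold lower number from compound 2 to compound 4 (0.06 log units; that floor lies within the scatter). For compound 4 the estimated value is 65000 nM, with an expected range from 20000 nM to 90000 nM.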

Compound 4, half-maximal cytotoxic concentration: > 3000 nM
Compound 4 gave a limit, no number; the forecaster's own chance of this, stated with the estimate: 65%; the middle value lies beyond the limit too.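

In this assay compound 4 gives > 3000 nM, which is a limit and not a number. Compound 2 also stands at a limit, > 76000 nM, so the step from compound 2 to compound 4 cannot be read. The compounds shown leave open whether adding ethyl changes the tolerated concentration at all, and by how much.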